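This account rests on a few compounds, and the source may have more. Where it says the series, first, only, none or still open, it means among the compounds named here.

Compound 1 `CN(C(=O)NC(=O)c1ccc(Cl)c(Cl)c1)c1nc(C(F)(F)F)c(C(=O)N/N=C/c2ccc([N+](=O)[O-])cc2)s1` and compound 2 `CN(C(=O)NC(=O)c1ccc(F)c(F)c1)c1nc(C(F)(F)F)c(C(=O)N/N=C/c2cccc(C(F)(F)F)c2)s1` share a core and differ at two places. In a functional assay on HepG2 cells (Homo sapiens) for inhibition, read by MTT assay, with a stated time of 72 h (a higher number here means a weaker inhibitor, a lower number a stronger inhibitor), compound 1 gives 6.85 ug/mL, and compound 2 gives 5.6 ug/mL; compound 2 has the lower of the two numbers, but the gap to compound 1 lies within the scatter. Compound 3 `CN(C(=O)NC(=O)c1ccc(F)c(F)c1)c1nc(C(F)(F)F)c(C(=O)N/N=C/c2ccc([N+](=O)[O-])cc2)s1` is compound 2 with 4-nitrophenyl in place of 3-(trifluoromethyl)phenyl on a carbon with a double bond to nitrogen. Within the data shown here, no measured pair isolates this change, so the step of a 1.1-fold higher number from compound 2 to compound 3 (0.03 log units; within the scatter) is expected to stay within the scatter, with no clear direction. Compound 3 is therefore estimated at 6 ug/mL, likely between 3 ug/mL and 12 ug/mL.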

Compound 3, half-maximal inhibitory concentration: 6.23 ug/mL
Beside the measured number, compound 3's estimate is 1.0-fold (0.02 log units) below it; the range from low to high includes it.
By their numbers in this assay, from the lowest: compounds 2, 3 and 1 (each within the scatter of the next).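

In this assay, among these compounds, 4-nitrophenyl in place of 3-(trifluoromethyl)phenyl gives a 1.1-fold higher number from compound 2 to compound 3 (0.05 log units; within the scatter) and 3,4-difluorophenyl in place of 3,4-dichlorophenyl gives a 1.1-fold lower number from compound 1 to compound 3 (0.04 log units; within the scatter) as the only change on a carbonyl carbon. Each place now has a pair that differs there alone, and neither change leaves the scatter. No measurement on hand explains this result. Still open, as far as these compounds go, is whether a different kind of group at either place, such as an amine or a carboxylic acid, would give a step beyond the scatter.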